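The compounds below may be only part of what the source reports. "The series", "measured", "known", "first", "only" and "open" are said of these compounds alone.

Working notes on the series, values in a physicochemical assay for solubility, read by HPLC, in simulated intestinal fluid, with a stated time of 16 h, at pH 6.5; on this read-out higher numbers stand for higher solubility and lower numbers for lower solubility:

- compound 1 `CC[C@@H](c1ccccc1)n1nc(C(=O)NC)cc1C(=O)N[C@H]1[C@@H]2C[C@@H](O)C[C@@H]21`: 56 ug/mL
- compound 2 `CNC(=O)c1cc(C(=O)N[C@H]2CC[C@H](O)CC2)c([C@@H](C)c2cccc(C)c2)o1`: > 1000 ug/mL (a limit)
- compound 3 `CC[C@@H](c1ccccc1)n1nc(C(=O)NC)cc1C(=O)N[C@H]1CC[C@H](O)CC1`: > 1000 ug/mL (a limit)

Compound 2 reads > 1000 ug/mL in this assay, and this is a limit of the assay, not a number. The starting point is therefore known only as a limit, and the series already meets (the limit of > 1000 ug/mL in this assay, at which 2 of the 3 values shown sit).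

The change to compound 4 `CNC(=O)c1cc(C(=O)N[C@H]2CC[C@H](O)CC2)c([C@@H](C)c2ccc(C)cc2)o1` is 4-methylphenyl in place of 3-methylphenyl on a saturated chain carbon bound to an aromatic carbon and a saturated chain carbon. In words, 4-methylphenyl stands in place of 3-methylphenyl on a saturated chain carbon bound to an aromatic carbon and a saturated chain carbon.

For the measured compounds named here, only one measured step is available: an at least 17-fold higher number from compound 1 to compound 3 (1.25 log units; beyond the scatter). That step is large, but it changes the group on an amide-type nitrogen, not the place changed here. It bears only indirectly, as compound 2 and compound 4 carry the same group on that nitrogen as compound 3. Going by the values given here, no measured step changes the methylphenyl group.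

The step expected in this assay is a number no higher from compound 2 to compound 4 (the limit leaves the size open), with nothing beyond the scatter foreseen in either direction. A further report as a limit is also expected to be likely. For compound 4 the estimated value is 1000 ug/mL, with an expected range from 350 ug/mL to 1500 ug/mL.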

Compound 4, solubility: > 1000 ug/mL
Compound 4 gave a limit, no number (the forecaster's own chance of this, stated with the estimate: 70%); the middle value sits exactly at the limit.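

Compound 2 and compound 4 both stand as limits in this assay, not as numbers, so no step between them can be read, and the series remains at its ceiling: the limit of > 1000 ug/mL in this assay, at which 3 of the 4 values shown sit.

The compounds shown leave open how far compound 2 and compound 4 lie past that limit, and whether 4-methylphenyl in place of 3-methylphenyl alters the read-out at all.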